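Swapping the amide tail for a chloroethyl chain

The compounds below may be only part of what the source reports. "The series", "measured", "known", "first", "only" and "open" are said of these compounds alone.

Compound 2 `CC(C)c1ccccc1OS(=O)(=O)c1ccc(NC(=O)C(C)(C)C)cc1`: 15000 nM
Compound 1 `CCCCCC(=O)Nc1ccc(S(=O)(=O)Oc2ccccc2C(C)C)cc1`: 6400 nM

In a functional assay on HT-29 cells (Homo sapiens) for antiproliferative activity, read by sulforhodamine B assay, with a stated time of 48 h (on this read-out lower numbers stand for stronger inhibition and higher numbers for weaker inhibition), compound 2 gives 15000 nM, the highest of the two numbers, while compound 1 gives 6400 nM. Within the data shown here, the only step known, a 2.3-fold higher number from compound 1 to compound 2 (0.37 log units; beyond the scatter), shows that the group on the carbonyl carbon matters modestly. Compound 3 `CC(C)c1ccccc1OS(=O)(=O)c1ccc(NC(=O)CCCl)cc1` carries 2-chloroethyl in place of tert-butyl on a carbonyl carbon, a short chain again rather than a branched group. Judged by the step from compound 1 to compound 2, a modest move back toward a lower number is expected, as a 1.7-fold lower number from compound 2 to compound 3 (0.22 log units; within the scatter). Compound 3 is therefore estimated at 9000 nM, within 3000 nM to 30000 nM.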

Compound 3, half-maximal inhibitory concentration: 16000 nM
Beside the measured number, compound 3's estimate is 1.8-fold (0.25 log units) below it; low and high end bracket the measured number.
By their numbers in this assay, from the lowest: compound 1; then compounds 2 and 3 (each within the scatter of the next).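

Putting 2-chloroethyl in place of tert-butyl on the carbonyl carbon gives only a 1.1-fold higher number from compound 2 to compound 3 (0.03 log units; within the scatter), so these two different tails cannot be told apart here. Chloro in place of propyl on the chain, two bonds along from the carbonyl carbon, gives a 2.5-fold higher number from compound 1 to compound 3 (0.40 log units; beyond the scatter), a modest step that leaves the pentyl tail of compound 1 with the lowest number. No available evidence explains these numbers.

As far as these compounds go, whether chain length or the chlorine matters more remains open. So does the effect of a longer chain, such as octyl, or of an amine at the chain end.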